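This account rests on a few compounds, and the source may have more. Where it says the series, first, only, none or still open, it means among the compounds named here.

In an ADME assay on Huh-7 cells (Homo sapiens) for cytotoxicity, with a stated time of 72 h (a higher number here means that more compound is tolerated, a lower number that less compound is tolerated), compound 3, whose structure is `CC(C)CCn1nc(-c2ccccc2)c(O)c(C2=NS(=O)(=O)c3cc(NS(C)(=O)=O)ccc3N2)c1=O`, is known only as a limit: compound 3 gives > 1000 nM, so its true value is not a number but a floor. Two further compounds share the same core. Compound 1, `CC(C)CCn1nc(-c2cccs2)c(O)c(C2=NS(=O)(=O)c3cc(NS(=O)(=O)C4CC4)ccc3N2)c1=O`, is likewise known only as a limit, and compound 1 gives > 1000 nM in this assay. Compound 2, `CC(C)CCn1nc(-c2cccs2)c(O)c(C2=NS(=O)(=O)c3cc(S(N)(=O)=O)ccc3N2)c1=O`, is also known only as a limit, and compound 2 gives > 33000 nM in this assay. Within the data shown here, the single step between two measured compounds, a step that the two limits leave unreadable from compound 1 to compound 2, cannot be sized because the limit of > 1000 nM in this assay, at which 2 of the 3 values shown sit, and the limit of > 33000 nM in this assay, at which 1 of the 3 values shown sits, both cap the readings rather than state them.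

Compound 4, `CC(C)CCn1nc(CCC(F)(F)F)c(O)c(C2=NS(=O)(=O)c3cc(NS(C)(=O)=O)ccc3N2)c1=O`, has not yet been measured. It differs from compound 3 by 3,3,3-trifluoropropyl in place of phenyl on an aromatic carbon. Among the measured compounds shown here, no measured step covers this change; the only measured step touches a different position and is itself unreadable. The expectation therefore rests on compound 3 alone, whose reading is a limit, and on the two other compounds, which also sit at limits. Compound 4 is expected to give about 3000 nM, within the range 1000 nM to 33000 nM, most probably again only as a limit. The step that the limit leaves unreadable from compound 3 to compound 4 is thus expected to be no change beyond the scatter.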

Compound 4, half-maximal cytotoxic concentration: > 33000 nM
Compound 4 gave a limit, no number; the forecaster's own chance of this, stated with the estimate: 80%; middle value at least 11-fold (1.04 log units) away from the limit.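

In this assay compound 3 and compound 4 are each known only as a limit, and the step between them cannot be read. The compounds shown leave open where the true values of compound 3 and compound 4 lie, and whether 3,3,3-trifluoropropyl in place of phenyl changes the tolerated concentration at all.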